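Oxolanyl carbamate replacing the benzyl amide in the pyrazole series

The compounds below may be only part of what the source reports. "The series", "measured", "known", "first", "only" and "open" are said of these compounds alone.

Compound 2 `Cc1cc(C(=O)NCc2ccccc2)nn1Cc1cc(Cl)ccc1OCc1ccccc1` is one of two compounds in the series with a number in an in vivo ADME assay on the whole organism (blood) for pharmacokinetics, with Rattus norvegicus as the target; a higher number here means faster removal of the compound, a lower number slower removal; the third, compound 1 `Cc1cc(C(=O)Nc2ccccc2)nn1Cc1cc(Cl)ccc1OCc1ccccc1`, has "not determined" (no result reported) there, so no number can be given for compound 1. Compound 2 gives 75 mL/min/kg in this assay, while compound 3 `Cc1cc(NC(=O)OCC(C)C)nn1Cc1cc(Cl)ccc1OCc1ccccc1` gives 124 mL/min/kg, and the two values lie within the scatter of each other, so no order between them can be read. Going by the values given here, the only single-point step available is a 1.7-fold higher number from compound 2 to compound 3 (0.22 log units; within the scatter), which exchanges the amide for a carbamate and shows nothing beyond the scatter.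

Compound 4 `Cc1cc(NC(=O)O[C@H]2CCOC2)nn1Cc1cc(Cl)ccc1OCc1ccccc1` carries the same exchange of amide for carbamate, now with the change ((((oxolan-3-yl)oxy)carbonyl)amino in place of benzylcarbamoyl on an aromatic carbon). Among the compounds with values here, the step from compound 2 to compound 3 is the only one that bears on it, and it was small; the oxolanyl carbamate of compound 4 has no measured counterpart, so the alkyl part of the carbamate cannot be assessed. The expectation for compound 4 is therefore a number close to those of compound 2 and compound 3, with the estimated step of a 1.3-fold higher number from compound 2 to compound 4 (0.12 log units; within the scatter) staying within the scatter. For compound 4 in this assay the estimate is 100 mL/min/kg, with a range from 55 mL/min/kg to 180 mL/min/kg.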

Compound 4, clearance: 86 mL/min/kg
For compound 4 the middle estimate is 1.2-fold (0.07 log units) above the measured one, within the range that was stated.
By their numbers in this assay, from the lowest: compounds 2, 4 and 3 (each within the scatter of the next).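

In this assay, (((oxolan-3-yl)oxy)carbonyl)amino in place of benzylcarbamoyl on the aromatic carbon gives a 1.1-fold higher number from compound 2 to compound 4 (0.06 log units; within the scatter) and so adds a second carbamate that cannot be told apart from the benzyl amide. Going by these compounds alone, the alkyl part of the carbamate can now be read for the first time: oxolan-3-yl in place of isobutyl on the oxygen next to the carbonyl group gives a 1.4-fold lower number from compound 3 to compound 4 (0.16 log units; within the scatter) and also stays inside the scatter. Across compound 2, compound 3 and compound 4, neither the exchange of amide for carbamate nor the exchange of an open alkyl group for a five-membered non-aromatic ring with 1 hetero atom separates the numbers in this assay, and no order can be drawn among the three.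

On these data alone, whether any carbamate alkyl part can separate itself from these compounds remains open, for instance one carrying an amine or a carboxylic acid, or a longer chain. Also open, as far as these compounds go, is how the opposite configuration at the defined stereocentre of the oxolan-3-yl group would compare with compound 4, and no measurement available here offers an explanation for these numbers.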